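A Bromo Step Repeated on a Second Core

The source may report more compounds than this note shows. Statements on the series, on what has been measured and on what is new or still open speak of the compounds shown alone.

Compound 1, `CN(CCCn1c(=O)oc2ccccc21)Cc1ccccc1`, in an ADME assay on SH-SY5Y cells (Homo sapiens) for cytotoxicity, read by MTT assay, with a stated time of 72 h (a lower number here means a stronger inhibitor, a higher number a weaker inhibitor), gives > 100000 nM, which is a limit of the assay.
Compound 2, `CN(CCCn1c(=O)oc2cc(Br)ccc21)Cc1ccccc1`, in this assay gives 58800 nM.
Compound 3, `O=c1oc2ccccc2n1CCCN1Cc2ccccc2C1`, in this assay gives > 100000 nM, which is a limit of the assay.

From compound 1 to compound 2 the change is bromo in place of hydrogen on an aromatic carbon, and it gave an at least 1.7-fold lower number from compound 1 to compound 2 (0.23 log units; that floor lies within the scatter). This step cannot be sized more closely, since it starts from the limit of > 100000 nM in this assay, at which 2 of the 3 values shown sit. Compound 3 carries a different core from compound 1; the difference between the two cores is not broken down here.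

Compound 4, `O=c1oc2cc(Br)ccc2n1CCCN1Cc2ccccc2C1`, has not yet been measured. It differs from compound 3 by bromo in place of hydrogen on an aromatic carbon, the same change as from compound 1 to compound 2, at the same kind of place.

Going from compound 3 to compound 4, the step expected in this assay is an at least 1.6-fold lower number from compound 3 to compound 4 (0.22 log units; that floor lies within the scatter), resting on the step from compound 1 to compound 2 of an at least 1.7-fold lower number from compound 1 to compound 2 (0.23 log units; that floor lies within the scatter). For compound 4 the expected value is 60000 nM, estimated to lie between 30000 nM and 120000 nM, with a real chance that only a limit is reported.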

Compound 4, half-maximal inhibitory concentration: > 100000 nM
Compound 4: no number, only a limit; the forecaster's own chance of this, stated with the estimate: 45%; middle value at least 1.6-fold (0.22 log units) away from the limit.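

No step from compound 3 to compound 4 can be read in this assay, because each of the two compounds gives only a limit, and it is the same limit: the limit of > 100000 nM in this assay, at which 3 of the 4 values shown sit.

The compounds shown leave open whether bromo in place of hydrogen on an aromatic carbon changes the number at all on the core of compound 3.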